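A Methylphenyl Swap in a Cell Toxicity Test

A few compounds are considered here, and "the series" means these few. Any claim that something is new, unique, unknown or untested is made for them only; others in the source may bear on it.

Compound 1 `CC(C)=CCC1=C(OCc2cn(-c3cccnc3)nn2)C(=O)c2ccccc2C1=O`: 1030000 nM
Compound 2 `CC(C)=CCC1=C(OCc2cn(-c3ccc(C#N)cc3)nn2)C(=O)c2ccccc2C1=O`: 707000 nM

In an ADME assay on HepG2 cells (Homo sapiens) for cytotoxicity, read by MTT assay, with a stated time of 24 h (on this read-out higher numbers stand for lower toxicity in this test and lower numbers for higher toxicity in this test), compound 2 gives 707000 nM. Going by the values given here, its only measured neighbour is compound 1, and the step between them is a 1.5-fold lower number from compound 1 to compound 2 (0.16 log units; within the scatter), so the two values cannot be told apart.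

The next structure, compound 3 `CC(C)=CCC1=C(OCc2cn(-c3ccccc3C)nn2)C(=O)c2ccccc2C1=O`, keeps the shared core and changes one group: 2-methylphenyl in place of 4-cyanophenyl on an aromatic nitrogen. The group that enters carries no triple bond, and the place of exchange stays the same aromatic nitrogen.

Among the compounds with values here, only one measured step bears on this change. The step of a 1.5-fold lower number from compound 1 to compound 2 (0.16 log units; within the scatter) also exchanged one aromatic group for another on that nitrogen. One step is thin evidence, but it points to no change beyond the scatter in this assay. The estimated move is a 1.1-fold higher number from compound 2 to compound 3 (0.05 log units; within the scatter). For compound 3 the expected value is 800000 nM, with an estimated range of 400000 nM to 1500000 nM.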

Compound 3, half-maximal cytotoxic concentration: 256000 nM
Compound 3: the middle estimate sits 3.1-fold (0.49 log units) above what was measured; the whole stated range lies above it.
By their numbers in this assay, from the lowest: compound 3; then compounds 2 and 1 (each within the scatter of the next).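

In this assay, the group on the aromatic nitrogen can shift the result after all: the change to 2-methylphenyl gives a 2.8-fold lower number from compound 2 to compound 3 (0.44 log units; beyond the scatter), and measured against pyridin-3-yl it gives a 4.0-fold lower number from compound 1 to compound 3 (0.60 log units; beyond the scatter). Compound 1 and compound 2 could not be told apart, yet 2-methylphenyl stands apart from both groups they carry, on the side of higher toxicity in this test. Nothing in the data shown gives a reason for this shift.

Open, as far as these compounds go, is whether the methyl group is what counts, a question that a plain phenyl or a 4-methylphenyl group on the same nitrogen would bear on. Also open, from the compounds shown here alone, is how a ring carrying an amine or a carboxylic acid would read in this assay.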